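Moving the chlorine on the phenyl ring

The source may hold more compounds than are shown below. What is called first, only, known or untested is meant among the compounds shown, and "the series" means these compounds.

Compound 1 `Cc1ccccc1NNC(=O)c1ccccc1NS(=O)(=O)c1cnc(O)nc1O`: > 20000 nM
Compound 2 `Cc1cccc(NNC(=O)c2ccccc2NS(=O)(=O)c2cnc(O)nc2O)c1`: > 20000 nM
Compound 3 `O=C(NNc1ccccc1Cl)c1ccccc1NS(=O)(=O)c1cnc(O)nc1O`: 5480 nM

Within the data shown here, in a functional assay on A549 cells (Homo sapiens) for antiproliferative activity, read by MTT assay, with a stated time of 24 h (on this read-out lower numbers stand for stronger inhibition and higher numbers for weaker inhibition), compound 3 gives 5480 nM, the only true number so far. Compound 1 reaches only a limit, > 20000 nM. Compound 2 also reaches only a limit, > 20000 nM. Compound 4 `O=C(NNc1cccc(Cl)c1)c1ccccc1NS(=O)(=O)c1cnc(O)nc1O` has 3-chlorophenyl in place of 2-chlorophenyl on an amine nitrogen. The matching change among the methyl compounds, a step that the two limits leave unreadable from compound 1 to compound 2, cannot guide the size. Two other steps, an at least 3.6-fold lower number from compound 1 to compound 3 (0.56 log units; beyond the scatter) and an at least 3.6-fold lower number from compound 2 to compound 3 (0.56 log units; beyond the scatter), show that both methyl compounds fall short of the chloro compound, whichever position their methyl holds. A small shift towards weaker inhibition is therefore expected, estimated as a 1.5-fold higher number from compound 3 to compound 4 (0.16 log units; within the scatter). For compound 4 the estimated value is 8000 nM, with an expected range of 3000 nM to 20000 nM.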

Compound 4, half-maximal inhibitory concentration: 5290 nM
Compound 4: the middle estimate sits 1.5-fold (0.18 log units) above what was measured; the range from low to high includes it.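

In this assay, 3-chlorophenyl and 2-chlorophenyl on the amine nitrogen cannot be told apart, with a 1.0-fold lower number from compound 3 to compound 4 (0.02 log units; within the scatter). Compound 4 also stands clear of both methyl compounds, with an at least 3.7-fold lower number from compound 2 to compound 4 (0.57 log units; beyond the scatter) and an at least 3.7-fold lower number from compound 1 to compound 4 (0.57 log units; beyond the scatter). Chloro in place of methyl therefore gives a lower number at both ring positions, not just one: the same change on two cores in this assay, an at least 3.6-fold lower number (0.56 log units; beyond the scatter) from compound 1 to compound 3 and an at least 3.7-fold lower number (0.57 log units; beyond the scatter) from compound 2 to compound 4; the limit leaves it open whether they differ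

As far as these compounds go, the true size of these steps stays open, as they rest on a limit of the assay: the limit of > 20000 nM in this assay, at which 2 of the 4 values shown sit. Also open is how bromo, methoxy or an amine in place of the chlorine would read.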